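Trimming the side chain: compound 3 to compound 4

The compounds below may be only part of what the source reports. "The series", "measured", "known", "first", "only" and "open" are said of these compounds alone.

Measured in a functional assay on MCF7 cells (Homo sapiens) for cytotoxicity, read by MTT assay, with a stated time of 72 h; a higher number here means a weaker inhibitor, a lower number a stronger inhibitor:
- compound 1 `COc1ncc(-c2ccc3nc(NC(=O)NCCN4CCCC4)nn3c2)cc1NS(=O)(=O)c1ccc(F)cc1`: 380 nM
- compound 2 `COc1ncc(-c2ccc3nc(NC(=O)NCC(=O)N4CCCC4)nn3c2)cc1NS(=O)(=O)c1ccc(F)cc1`: 2130 nM
- compound 3 `COc1ncc(-c2ccc3nc(NC(=O)NCCN(C)C)nn3c2)cc1NS(=O)(=O)c1ccc(F)cc1`: 560 nM

The standing so far rests on two steps: a 1.5-fold higher number from compound 1 to compound 3 (0.17 log units; within the scatter), and a 3.8-fold lower number from compound 2 to compound 3 (0.58 log units; beyond the scatter). Compound 3 thus stands with compound 1 and apart from compound 2.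

Compound 4 `CNC(=O)Nc1nc2ccc(-c3cnc(OC)c(NS(=O)(=O)c4ccc(F)cc4)c3)cn2n1` carries hydrogen in place of (dimethylamino)methyl on a saturated chain carbon bound to an amide-type nitrogen. For the measured compounds named here, no measured step removes this group outright. The nearest evidence is the replacement at the same carbon, a 5.6-fold higher number from compound 1 to compound 2 (0.75 log units; beyond the scatter). The expected move is therefore modest and upward, a 2.1-fold higher number from compound 3 to compound 4 (0.33 log units; beyond the scatter), with wide uncertainty. For compound 4 the estimated value is 1200 nM, with an expected range of 300 nM to 5000 nM.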

Compound 4, half-maximal inhibitory concentration: 250 nM
Beside the measured number, compound 4's estimate is 4.8-fold (0.68 log units) above it; the whole stated range lies above it.
By their numbers in this assay, from the lowest: compounds 4, 1 and 3 (each within the scatter of the next, the first and the last beyond it); then compound 2.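

Removing the (dimethylamino)methyl group from this saturated chain carbon does not cost activity in this assay: the result is a 2.2-fold lower number from compound 3 to compound 4 (0.35 log units; beyond the scatter) and, against the carbonyl-bearing side chain, an 8.5-fold lower number from compound 2 to compound 4 (0.93 log units; beyond the scatter) in the same direction. With the pyrrolidine side chain, the same trimming gives a 1.5-fold lower number from compound 1 to compound 4 (0.18 log units; within the scatter) and so separates neither compound, showing that a terminal amine is not required to reach this level of activity. Nothing measured here explains these steps.

Still open, as far as these compounds go, is whether an ethyl group or a longer unbranched alkyl chain at this carbon holds this level. From the compounds shown here alone, a carboxylic acid there is equally open.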